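Swapping a methyl for hydrogen on an amide nitrogen

A few compounds are considered here, and "the series" means these few. Any claim that something is new, unique, unknown or untested is made for them only; others in the source may bear on it.

Measured in a functional assay on the whole organism with Mus musculus as the target; a lower number here means that less compound is needed, a higher number that more compound is needed for the effect:
Compound 1 `CCN(C)C(=O)/C=C1\CCc2c(F)cc(F)cc21`: 56 mg/kg
Compound 2 `CNC(=O)/C=C1\CCc2cc(F)c(F)cc21`: 96 mg/kg

The numbers for compound 1 and compound 2 lie within the usual scatter of each other, so they cannot be ranked. Compound 3 `NC(=O)/C=C1\CCc2cc(F)c(F)cc21` comes from compound 2 by a single change: hydrogen in place of methyl on an amide-type nitrogen. Among the measured compounds shown here, no measured pair shows this change, so the data give no size for it. The estimated step of a 1.1-fold lower number from compound 2 to compound 3 (0.03 log units; within the scatter) is expected to stay within the scatter, with no clear direction. For compound 3 the expected value is 90 mg/kg, with an estimated range of 40 mg/kg to 200 mg/kg.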

Compound 3, dose for half-maximal effect: 64 mg/kg
For compound 3 the middle estimate is 1.4-fold (0.15 log units) above the measured one; the range from low to high includes it.
By their numbers in this assay, from the lowest: compounds 1, 3 and 2 (each within the scatter of the next).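

Among the compounds shown here, compound 2 and compound 3 form the only measured pair that differs at just this amide-type nitrogen, and in this assay hydrogen in place of methyl gives a 1.5-fold lower number from compound 2 to compound 3 (0.18 log units; within the scatter) as its step. At this position, then, the methyl can be lost without a change that this whole-animal read-out can resolve. No supporting measurement offers an explanation for this result.

On these data alone, the effect of a longer chain, such as propyl, on this nitrogen remains open. So does that of a carboxylic acid in place of the amide.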